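Moving the methoxy group around the ring of a weak antiproliferative series

The source may report more compounds than this note shows. Statements on the series, on what has been measured and on what is new or still open speak of the compounds shown alone.

Compound 2 `COc1ccc(/C=C2/C(C)=C(CC(=O)O)c3cc(F)ccc32)cc1` shows, in a functional assay on MDCK cells (Canis lupus familiaris) for antiproliferative activity (on this read-out lower numbers stand for stronger inhibition and higher numbers for weaker inhibition), a number of 310000 nM. Compound 1 `COc1cccc(/C=C2/C(C)=C(CC(=O)O)c3cc(F)ccc32)c1` gives 300000 nM, and the step of a 1.0-fold higher number from compound 1 to compound 2 (0.01 log units; within the scatter) is a flat one. Going by the values given here, compound 2 therefore stands at the highest of the two numbers so far, though its nearest neighbour, compound 1, sits so close that the two cannot be told apart.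

Compound 3 `COc1ccccc1/C=C1/C(C)=C(CC(=O)O)c2cc(F)ccc21` is the next member of the series. Relative to compound 2 it carries 2-methoxyphenyl in place of 4-methoxyphenyl on a double-bonded chain carbon bound to a double-bonded ring carbon. Among the compounds with values here, the only measured step that bears on this change is the one from compound 1 to compound 2, which also moved the methoxy group to a different position on the same phenyl ring and left the number essentially unchanged. On that evidence no step beyond the scatter is expected in this assay for the third position either, in neither direction.

The expected step of a 1.0-fold lower number from compound 2 to compound 3 (0.01 log units; within the scatter) is therefore close to none, and compound 3 is estimated at 300000 nM, with a likely range from 150000 nM to 600000 nM.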

Compound 3, half-maximal inhibitory concentration: 360000 nM
Beside the measured number, compound 3's estimate is 1.2-fold (0.08 log units) below it; low and high end bracket the measured number.
By their numbers in this assay, from the lowest: compounds 1, 2 and 3 (each within the scatter of the next).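

Going by these compounds alone, with this result, the three groups 2-methoxyphenyl, 3-methoxyphenyl and 4-methoxyphenyl can all be compared on the same double-bonded chain carbon in this assay, where the earlier compounds offered only one comparison: the change from 4-methoxyphenyl to 2-methoxyphenyl gives a 1.2-fold higher number from compound 2 to compound 3 (0.06 log units; within the scatter), and the change from 3-methoxyphenyl to 2-methoxyphenyl gives a 1.2-fold higher number from compound 1 to compound 3 (0.08 log units; within the scatter). Together with the earlier step, this means that every pair among the three compounds now lies within the scatter, so on this read-out the placement of the methoxy group on this phenyl ring does not separate compound 1, compound 2 and compound 3. Nothing available here offers an explanation for this flat result.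

Going by these compounds, all three compounds keep a methoxy group on this phenyl ring, so it remains open whether the number would respond to a different group there, such as a hydroxyl, an amine or a longer chain like ethoxy. The shared core also stays unchanged throughout, leaving open what would happen if its carboxylic acid gave way to an amide or its fluorine to a chlorine.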